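The source may hold more compounds than are shown below. What is called first, only, known or untested is meant among the compounds shown, and "the series" means these compounds.

In a functional assay on LOX IMVI cells (Homo sapiens) for inhibition, read by sulforhodamine B assay, with a stated time of 48 h (on this read-out lower numbers stand for higher toxicity in this test and higher numbers for lower toxicity in this test), compound 1 `COc1cc(-c2nn(-c3cccc(NC(=O)Nc4cc(C(F)(F)F)cc(C(F)(F)F)c4)c3)cc2-c2ccncc2)ccc1Cl` gives 2940 nM. Compound 2 `O=C(Nc1cccc(-n2cc(-c3ccncc3)c(-c3ccc(Cl)c(O)c3)n2)c1)Nc1ccc(Cl)c(Cl)c1` gives 15000 nM in this assay, so compound 1 has the lower of the two numbers, and the gap between the two lies beyond the scatter. Compound 3 `COc1cc(-c2nn(-c3cccc(NC(=O)Nc4cccc(C(F)(F)F)c4)c3)cc2-c2ccncc2)ccc1Cl` differs from compound 1 in a single place: hydrogen in place of trifluoromethyl on an aromatic carbon. Among the compounds with values here, no measured pair shows this change, so nothing about its effect is known here. The step from compound 1 to compound 3 is expected to be a modest one toward a higher number, a 1.7-fold higher number from compound 1 to compound 3 (0.23 log units; within the scatter). Compound 3 is therefore estimated at 5000 nM, within 2000 nM to 15000 nM.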

Compound 3, concentration lethal to 50% of the cells: 3460 nM
Estimate against measurement, compound 3: 1.4-fold (0.16 log units) above, and the stated range covers the measured number.
By their numbers in this assay, from the lowest: compounds 1 and 3 (each within the scatter of the next); then compound 2.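

In this assay, hydrogen in place of trifluoromethyl on this aromatic carbon gives a 1.2-fold higher number from compound 1 to compound 3 (0.07 log units; within the scatter), a step within the scatter. Within the data shown here, this is the first single-place comparison here, and it shows that compound 3 keeps the toxicity of compound 1 in this test without this trifluoromethyl group. Nothing available explains this result. The compounds shown leave open whether an amine or a carboxylic acid on this aromatic carbon would give a step beyond the scatter. They also leave open what replacing the remaining trifluoromethyl group of compound 3 with hydrogen would do.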